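Changing the charged head group at the end of the chain

A few compounds are considered here, and "the series" means these few. Any claim that something is new, unique, unknown or untested is made for them only; others in the source may bear on it.

Measured compounds in an assay on LX2 cells for inhibition of COL1A1 promoter (Homo sapiens), read by a luciferase reporter, with a stated time of 24 h, tested at 50 uM; a higher number here means a stronger effect of the compound at the concentration tested, a lower number a weaker effect:
compound 1, `Cc1cc(OCCCCCCC[n+]2ccccc2)cc(-n2cc(C(=O)Nc3cc(F)cc(F)c3)c(=O)c3ccc(N(C)C)nc32)c1`: 61%
compound 2, `Cc1cc(OCCCCCCC[N+]2(C)CCN(C)CC2)cc(-n2cc(C(=O)Nc3cc(F)cc(F)c3)c(=O)c3ccc(N(C)C)nc32)c1`: 38.2%

Within the data shown here, compound 2 stands lowest of the two numbers measured so far; its nearest neighbour is compound 1, and the only measured step, a number 22.8 percentage points lower from compound 1 to compound 2 (beyond the scatter), separates them.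

Compound 3, `CC[N+]1(CCCCCCCOc2cc(C)cc(-n3cc(C(=O)Nc4cc(F)cc(F)c4)c(=O)c4ccc(N(C)C)nc43)c2)CCCC1`, has not yet been measured. It differs from compound 2 only at the end of the chain: a group of 7 heavy atoms (6 carbon, 1 nitrogen; one five-membered non-aromatic ring with 1 hetero atom) in place of a group of 8 heavy atoms (6 carbon, 2 nitrogen; one six-membered non-aromatic ring with 2 hetero atoms), on a saturated chain carbon, seven bonds along the chain from an oxygen on an aromatic ring. In the same sense, the measured step replaced an aromatic ring bearing one nitrogen with a non-aromatic six-membered ring bearing two nitrogens and cost a modest amount of inhibition. Compound 3 keeps a non-aromatic charged ring, so the measured step bears on it only loosely: it tells what happens when the aromatic ring is lost, not what a smaller ring with a single nitrogen does. Among the measured compounds shown here, no measured pair isolates that change, so no step beyond the scatter is firmly expected in this assay, though a small upward drift is plausible.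

The step of a number 6.8 percentage points higher from compound 2 to compound 3 (within the scatter) is therefore expected to be small. Compound 3 is estimated to give 45%, with a range from 25% to 65%.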

Compound 3, a percentage reported as inhibition, at one concentration (the size of the read-out at that concentration, not a potency): 73.2%
The estimate for compound 3 lay 28.2 percentage points below the measured number; measured number above the stated range.
By their numbers in this assay, from the lowest: compound 2; then compound 1; then compound 3.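

The head group on the saturated chain carbon, seven bonds along the chain from an oxygen on an aromatic ring, proves able to move this assay strongly in both directions, even when the ring stays non-aromatic and the net charge stays +1: the read-out shows a number 35 percentage points higher from compound 2 to compound 3 (beyond the scatter) in a large step. Loss of the aromatic ring therefore does not by itself lower the read-out among these compounds, since the five-membered non-aromatic ring also exceeds the aromatic one with a number 12.2 percentage points higher from compound 1 to compound 3 (beyond the scatter) as a modest step beyond the scatter. No available evidence accounts for these differences.

The step between the two non-aromatic rings changes ring size, the number of ring nitrogens and the substituents on the charged nitrogen together, so the compounds shown cannot say which of these matters. From the compounds shown here alone, it also remains open how a piperidine ring, a morpholine ring or a carboxylic acid at the end of the chain would fare, and a read-out at one concentration gives no potency for any of them.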